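Side-chain amides and amines in the antiproliferative series

The source may report more compounds than this note shows. Statements on the series, on what has been measured and on what is new or still open speak of the compounds shown alone.

- compound 1 `CNC(=O)C[C@@H]1C[C@@H](c2ccc(Cl)c(Cl)c2)[C@H](NC(=O)c2cc(-c3c(Cl)cnn3C)c(Cl)o2)CN1` gives 40 nM
- compound 2 `C=CC[C@@H]1C[C@@H](c2ccc(Cl)c(Cl)c2)[C@H](NC(=O)c2cc(-c3c(Cl)cnn3C)c(Cl)o2)CN1` gives 160 nM
- compound 3 `CN(C)CC[C@@H]1C[C@@H](c2ccc(Cl)c(Cl)c2)[C@H](NC(=O)c2cc(-c3c(Cl)cnn3C)c(Cl)o2)CN1` gives 1930 nM

All three values come from a functional assay on LNCaP cells (Homo sapiens) for antiproliferative activity; a lower number here means a stronger inhibitor, a higher number a weaker inhibitor. Compound 3 has the highest number of the three. Its nearest neighbour is compound 2, with a 12-fold higher number from compound 2 to compound 3 (1.08 log units; beyond the scatter), and the furthest is compound 1, with a 48-fold higher number from compound 1 to compound 3 (1.68 log units; beyond the scatter).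

Compound 4 `Cn1ncc(Cl)c1-c1cc(C(=O)N[C@@H]2CN[C@H](CC(=O)NCC(O)CO)C[C@H]2c2ccc(Cl)c(Cl)c2)oc1Cl` has not yet been measured. It carries (2,3-dihydroxypropyl)carbamoyl in place of (dimethylamino)methyl on a saturated chain carbon bound to a saturated ring carbon and is otherwise the same as compound 3.

Among the measured compounds shown here, the step that bears most directly is a 48-fold higher number from compound 1 to compound 3 (1.68 log units; beyond the scatter), since compound 1 is the only measured compound with a carbamoyl group at this place. Read in reverse, it points to a large fall in this assay. The modest 4.0-fold higher number from compound 1 to compound 2 (0.60 log units; beyond the scatter) shows a smaller change away from methylcarbamoyl. For the measured compounds named here, no measured compound shows what the dihydroxypropyl part does, so part of that fall may not carry over.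

The expected result is a large step down, estimated as a 28-fold lower number from compound 3 to compound 4 (1.44 log units; beyond the scatter). The estimate for compound 4 is 70 nM, with an expected range of 25 nM to 250 nM.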

Compound 4, half-maximal inhibitory concentration: 660 nM
Compound 4: middle estimate off by 9.4-fold (0.97 log units), on the low side; measured number above the stated range.
By their numbers in this assay, from the lowest: compound 1; then compound 2; then compound 4; then compound 3.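

In this assay, the (2,3-dihydroxypropyl)carbamoyl group gives only a partial return towards the methylcarbamoyl result, with a 2.9-fold lower number from compound 3 to compound 4 (0.47 log units; beyond the scatter). A carbamoyl group at this place is therefore not enough on its own to give the low number: 1,2-dihydroxyethyl in place of hydrogen on a saturated chain carbon bound to an amide-type nitrogen gives a 17-fold higher number from compound 1 to compound 4 (1.22 log units; beyond the scatter), and the replacement of vinyl, which has no carbamoyl, gives a 4.1-fold higher number from compound 2 to compound 4 (0.62 log units; beyond the scatter). No measurement at hand bears on the reason for these steps.

The compounds shown do not separate the effect of the two hydroxyl groups from that of the longer chain on the amide nitrogen. An unsubstituted carboxamide or a 2-methoxyethyl amide at the same place would bear on that question.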